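The compounds below may be only part of what the source reports. "The series", "measured", "known", "first", "only" and "open" are said of these compounds alone.

Measured so far in a functional assay (uterus) for inhibition, with Rattus norvegicus as the target; a lower number here means that less compound is needed, a higher number that more compound is needed for the effect:
compound 1 `Brc1cncc2nccn12` gives 0.29 nM
compound 2 `OCc1cn2ccncc2n1` gives 2.7 nM
compound 3 `NC(=O)c1cn2ccncc2n1` gives 1.5 nM

Compound 1 has the lowest number of the three, beyond the scatter from both others. Compound 4 `N#Cc1cn2c(Br)cncc2n1` has cyano in place of hydrogen on an aromatic carbon. Among the compounds with values here, the only measured step is a 1.8-fold lower number from compound 2 to compound 3 (0.26 log units; within the scatter), carbamoyl in place of hydroxymethyl on an aromatic carbon. Within the data shown here, it is a different exchange, and no measured step replaces hydrogen or introduces cyano, so its support is weak. Only a small rise in this assay is therefore expected, with the estimated step being a 1.7-fold higher number from compound 1 to compound 4 (0.24 log units; within the scatter). For compound 4 the estimated value is 0.5 nM, with an expected range of 0.1 nM to 2.5 nM.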

Compound 4, concentration for half-maximal effect: 0.78 nM
Estimate against measurement, compound 4: 1.6-fold (0.19 log units) below, and the stated range covers the measured number.
By their numbers in this assay, from the lowest: compound 1; then compounds 4, 3 and 2 (each within the scatter of the next, the first and the last beyond it).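

In this assay, cyano in place of hydrogen on this aromatic carbon of the five-membered ring gives a 2.7-fold higher number from compound 1 to compound 4 (0.43 log units; beyond the scatter), a modest step, and compound 4 still reads 0.78 nM. Within the data shown here, this is the first measured step that starts from hydrogen at this carbon, so a small group with a triple bond can enter here at a modest cost in this read-out. No supporting data bear on why the number rises.

On these data alone, whether an amine or a carboxylic acid on this carbon would keep the number as low remains open. So does whether cyano would produce a step of similar size in a core without bromine.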